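Removing a Methyl from the Amide Side Chain

The source may report more compounds than this note shows. Statements on the series, on what has been measured and on what is new or still open speak of the compounds shown alone.

Measured compounds:
compound 1 `CCC(=O)N1CCc2cc(CNC(=O)c3ccccc3)ccc21`: 87%
compound 2 `CC(C)C(=O)N1CCc2cc(CNC(=O)c3ccc(F)cc3)ccc21`: 88%
compound 3 `CC(C)C(=O)N1CCc2cc(CNC(=O)c3ccccc3)ccc21`: 100%

All three were tested in an assay on HEK293 cells for inhibition of Indoleamine 2,3-dioxygenase 1 (Homo sapiens), tested at 10 uM; a higher number here means more inhibition at the concentration tested (going by the name of the read-out), a lower number less inhibition. Compound 3 gives the highest number of the three, and the step of a number 13 percentage points lower from compound 3 to compound 1 (beyond the scatter) is described as hydrogen in place of methyl on a saturated chain carbon bound to a carbonyl carbon and a saturated chain carbon. The cores of compound 2 and compound 3 differ by fluoro in place of hydrogen on an aromatic carbon, and the step of a number 12 percentage points higher from compound 2 to compound 3 (beyond the scatter) runs in the opposite direction.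

Compound 4 `CCC(=O)N1CCc2cc(CNC(=O)c3ccc(F)cc3)ccc21` has not yet been measured in this assay. It differs from compound 2 by hydrogen in place of methyl on a saturated chain carbon bound to a carbonyl carbon and a saturated chain carbon, the same change, at the same place, that turns compound 3 into compound 1. Among the measured compounds shown here, on the one measured step for this change, compound 4 is expected to fall below compound 2 by about a number 12 percentage points lower from compound 2 to compound 4 (beyond the scatter), because a number 13 percentage points lower from compound 3 to compound 1 (beyond the scatter) stands as the only precedent; whether the change acts alike on the fluoro-bearing core is not known. The estimate for compound 4 in this assay is 76%, with a range from 60% to 90%.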

Compound 4, a percentage reported as inhibition, at one concentration (the size of the read-out at that concentration, not a potency): 96%
For compound 4 the middle estimate is 20 percentage points below the measured one, and the stated range ends below it.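

In this assay, isopropyl to ethyl on the fluoro-bearing core gave a number 8 percentage points higher from compound 2 to compound 4 (within the scatter), so the drop seen on the core without fluoro did not carry over: the same change on two cores in this assay, a number 13 percentage points lower (beyond the scatter) from compound 3 to compound 1 and a number 8 percentage points higher (within the scatter) from compound 2 to compound 4, 21 percentage points apart, beyond the scatter of two such steps. Read through the other change, fluoro in place of hydrogen on an aromatic carbon gave a number 9 percentage points higher from compound 1 to compound 4 (within the scatter) on the propanoyl core, and this step also fails to match its counterpart on the isopropylcarbonyl core: the same change on two cores in this assay, a number 12 percentage points higher (beyond the scatter) from compound 2 to compound 3 and a number 9 percentage points lower (within the scatter) from compound 4 to compound 1, 21 percentage points apart, beyond the scatter of two such steps. The four compounds thus show that neither step can be moved from one core to the other in this series on the strength of a single precedent, but with both new steps within the scatter they do not show that removing the methyl raises the number on the fluoro-bearing core, and they give no reason for the mismatch.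

The compounds shown leave open whether the same mismatch would appear with a longer chain in place of isopropyl, or with chloro or methoxy in place of fluoro. They also leave open how these readings at a single concentration relate to potency.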